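Working notes on the step from compound 1 to compound 4

The source may report more compounds than this note shows. Statements on the series, on what has been measured and on what is new or still open speak of the compounds shown alone.

Measured compounds:
compound 1 `COc1cc(Oc2cccc(Nc3ccccc3)c2)cc(OC)c1CNCc1ccc(Cl)cc1` — 3350 nM
compound 2 `COc1ccc(CNCc2c(OC)cc(Oc3cccc(Nc4ccccc4)c3)cc2OC)cc1` — 1890 nM
compound 3 `COc1ccc([C@@H](C)NCc2c(OC)cc(Oc3cccc(Nc4ccccc4)c3)c(OC)c2OC)cc1` — 1630 nM

These values come from a functional assay on HT-29 cells (Homo sapiens) for inhibition, read by MTT assay, with a stated time of 72 h; a lower number here means a stronger inhibitor, a higher number a weaker inhibitor. Compound 1 gives the highest number of the three; compound 2 lies within the scatter of it, compound 3 beyond it. Compound 4 `COc1ccc(CCCNCc2c(OC)cc(Oc3cccc(Nc4ccccc4)c3)cc2OC)cc1` differs from compound 1 by 2-(4-methoxyphenyl)ethyl in place of 4-chlorophenyl on a saturated chain carbon bound to an amine nitrogen. For the measured compounds named here, one measured step bears on this change: a 1.8-fold lower number from compound 1 to compound 2 (0.25 log units; within the scatter), which covers the exchange of chloro for methoxy. Going by the values given here, no measured pair covers the longer chain between the amine nitrogen and the ring, so that part is unsupported. For compound 4 a step of about a 1.8-fold lower number from compound 1 to compound 4 (0.25 log units; within the scatter) is expected, leaving it near compound 2. The estimate for compound 4 is 1900 nM, ranging from 800 nM to 4500 nM.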

Compound 4, half-maximal inhibitory concentration: 3320 nM
Compound 4: the middle estimate sits 1.7-fold (0.24 log units) below what was measured; low and high end bracket the measured number.
By their numbers in this assay, from the lowest: compounds 3, 2, 4 and 1 (each within the scatter of the next, the first and the last beyond it).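

The step of a 1.0-fold lower number from compound 1 to compound 4 (0.00 log units; within the scatter) and the step of a 1.8-fold higher number from compound 2 to compound 4 (0.24 log units; within the scatter) both lie within the scatter in this assay, so on a saturated chain carbon bound to an amine nitrogen, 2-(4-methoxyphenyl)ethyl is tolerated as well as 4-chlorophenyl or 4-methoxyphenyl. The longer chain, unsupported until now, thus produces no readable change across these three compounds. Nothing available explains this tolerance.

Still open, on these data alone, is whether any group at this place moves the number beyond the scatter, for instance a longer chain ending in the same ring, or a carboxylic acid in place of the ring.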